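Shortening the Linker: A Pyrimidine-to-Pyridine Swap Under Test

The compounds below may be only part of what the source reports. "The series", "measured", "known", "first", "only" and "open" are said of these compounds alone.

Measured so far:
Compound 1 `Cc1cccc(NC(=O)CCN2CCN(c3ccccn3)CC2)c1`: 612 nM
Compound 2 `Cc1cccc(NC(=O)CCN2CCN(c3ncccn3)CC2)c1`: 568 nM
Compound 3 `Cc1cccc(NC(=O)CN2CCN(c3ncccn3)CC2)c1`: 3.4 nM

In a functional assay on cells for agonist activity at D(4) dopamine receptor (Homo sapiens), read by TR-FRET and cAMP accumulation, with a stated time of 30 min (on this read-out lower numbers stand for an effect already at smaller amounts and higher numbers for an effect only at larger amounts of compound), compound 1 gives 612 nM and compound 2 gives 568 nM. The two differ in one place, described as pyridin-2-yl in place of pyrimidin-2-yl on an amine nitrogen in a ring, and the step is a 1.1-fold higher number from compound 2 to compound 1 (0.03 log units; within the scatter), so in this assay the two numbers cannot be told apart. Compound 3 has the lowest number of the three, with 3.4 nM; its steps to compound 2 and to compound 1 are both well beyond the scatter. The difference between the cores of compound 3 and compound 2 is not broken down here.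

Compound 4 `Cc1cccc(NC(=O)CN2CCN(c3ccccn3)CC2)c1` has not yet been measured. It is obtained from compound 3 by pyridin-2-yl in place of pyrimidin-2-yl on an amine nitrogen in a ring, the same change already seen from compound 2 to compound 1, at the same place. Because that earlier step was a 1.1-fold higher number from compound 2 to compound 1 (0.03 log units; within the scatter), compound 4 is expected to sit close to compound 3, and the expected step is a 1.2-fold higher number from compound 3 to compound 4 (0.07 log units; within the scatter). The estimate for compound 4 in this assay is 4 nM, with a likely range from 1.5 nM to 12 nM.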

Compound 4, half-maximal effective concentration: 3.6 nM
Beside the measured number, compound 4's estimate is 1.1-fold (0.05 log units) above it; measured number inside the range.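

In this assay, replacing pyrimidin-2-yl with pyridin-2-yl on the core of compound 3 gives a 1.1-fold higher number from compound 3 to compound 4 (0.02 log units; within the scatter), so the two numbers cannot be told apart. The same change made on the core of compound 2 leaves the numbers just as close, and the two steps agree even though compound 2 and compound 3 lie far apart on this read-out: the same change on two cores in this assay, a 1.1-fold higher number (0.03 log units; within the scatter) from compound 2 to compound 1 and a 1.1-fold higher number (0.02 log units; within the scatter) from compound 3 to compound 4, 1.0-fold (0.01 log units) apart, within the scatter of two such steps

Within this series, then, the swap carries over from one core to the other with no visible effect on the number, but two cores are a small sample, so this shows neither that the result holds on every related core nor why the swap makes so little difference, and it speaks only to this assay.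

On these data alone, it remains open whether a phenyl or pyrazin-2-yl ring on that same ring nitrogen would also leave the number in place. Also open, as far as these compounds go, is what a fluorine atom or a methoxy group added to the pyridin-2-yl ring would do.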